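A methanesulfonamido swap on compound 3

The compounds below may be only part of what the source reports. "The series", "measured", "known", "first", "only" and "open" are said of these compounds alone.

- Compound 1 `CC(=O)OC[C@H]1CN(c2ccc(-n3cc(-c4ccccn4)cn3)c(F)c2)C(=O)O1` gives > 400 ug/mL
- Compound 2 `O=C(OC[C@H]1CN(c2ccc(-n3cc(-c4ccccn4)cn3)c(F)c2)C(=O)O1)c1ccccc1` gives > 400 ug/mL
- Compound 3 `O=C1O[C@@H](Cn2ccnc2)CN1c1ccc(-n2cc(-c3ccccn3)cn2)c(F)c1` gives 350 ug/mL

All three were read in an ADME assay on L02 cells (Homo sapiens) for cytotoxicity, read by MTT assay, with a stated time of 48 h; a higher number here means a weaker inhibitor, a lower number a stronger inhibitor. For compound 1, > 400 ug/mL is a limit of the assay and not a number. For compound 2, > 400 ug/mL is likewise a limit. Among the compounds with values here, compound 3, at 350 ug/mL, holds the only actual number in the set.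

Compound 4 `CS(=O)(=O)NC[C@H]1CN(c2ccc(-n3cc(-c4ccccn4)cn3)c(F)c2)C(=O)O1` differs from compound 3 by methanesulfonamido in place of 1H-imidazol-1-yl on a saturated chain carbon bound to a saturated ring carbon, with methanesulfonamido in place of 1H-imidazol-1-yl on a saturated chain carbon bound to a saturated ring carbon.

Two measured steps change this same place: an at least 1.1-fold lower number from compound 1 to compound 3 (0.05 log units; that floor lies within the scatter) and an at least 1.1-fold lower number from compound 2 to compound 3 (0.05 log units; that floor lies within the scatter). Neither shows a change beyond the scatter, while a step that the two limits leave unreadable from compound 1 to compound 2 cannot be sized at all. The expected change is therefore small, namely a 1.1-fold higher number from compound 3 to compound 4 (0.05 log units; within the scatter), with no step beyond the scatter anticipated. Compound 4 is estimated at 390 ug/mL, with an expected range of 240 ug/mL to 620 ug/mL, and the assay may report only a limit.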

Compound 4, half-maximal inhibitory concentration: > 400 ug/mL
Compound 4 gave a limit, no number (the forecaster's own chance of this, stated with the estimate: 45%); at least 1.0-fold (0.01 log units) between middle value and limit.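

In this assay, replacing the ring of 1H-imidazol-1-yl with methanesulfonamido, which has no ring and brings a hydrogen-bond donor, gives an at least 1.1-fold higher number from compound 3 to compound 4 (0.05 log units; that floor lies within the scatter). Compound 4 therefore gives a limit of the assay and not a number, as compound 1 and compound 2 also do, which extends this outcome from the two esters to a sulfonamide at this place. The steps from compound 1 and from compound 2 to compound 4 cannot be read, and the true size of any difference at this position stays hidden because of the limit: the limit of > 400 ug/mL in this assay, at which 3 of the 4 values shown sit.

Going by these compounds, it remains open whether any group on this saturated chain carbon can move the number beyond the scatter. An amine, a carboxylic acid or a longer chain ending in methanesulfonamido would each put that question to the same core.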